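Adding a chloro to the sulfonyl ring of compound 3

The source may hold more compounds than are shown below. What is called first, only, known or untested is meant among the compounds shown, and "the series" means these compounds.

Of the compounds shown here, three of one family have been tested in a functional assay on B16-F10 cells (Mus musculus) for antiproliferative activity, read by ELISA and MTT assay, with a stated time of 48 h; a higher number here means a weaker inhibitor, a lower number a stronger inhibitor. Within the data shown here, compound 1 `O=C(/C=C/c1ccc(F)cc1)NS(=O)(=O)c1ccc(Cl)cc1` gives 2.6 ug/mL and compound 2 `O=C(/C=C/c1ccc(Br)cc1)NS(=O)(=O)c1ccc(Cl)cc1` gives 5.2 ug/mL; the one step between them, a 2.0-fold higher number from compound 1 to compound 2 (0.30 log units; within the scatter), changes the ring that carries the cinnamoyl chain. Compound 3 `COc1ccc(/C=C/C(=O)NS(=O)(=O)c2ccccc2)cc1` gives 13.2 ug/mL, the highest of the three numbers: it is beyond the scatter above both compound 2 and compound 1, so on these numbers compound 3 is the weakest inhibitor.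

Compound 4 `COc1ccc(/C=C/C(=O)NS(=O)(=O)c2ccc(Cl)cc2)cc1` differs from compound 3 in one place: chloro in place of hydrogen on an aromatic carbon. This is the change of phenyl to 4-chlorophenyl on the sulfonyl side. Among the measured compounds shown here, no measured step covers this exact change; the step from compound 1 to compound 2 concerns the other ring and so does not bear on it directly. What the numbers do show is that the two compounds carrying a chloro on that ring, compound 1 and compound 2, both sit below compound 3. On that basis the number for compound 4 is expected to move down, as a 1.9-fold lower number from compound 3 to compound 4 (0.28 log units; within the scatter), though with little certainty. The estimate for compound 4 in this assay is 7 ug/mL, within a range from 3 ug/mL to 16 ug/mL.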

Compound 4, half-maximal inhibitory concentration: 5.3 ug/mL
Estimate against measurement, compound 4: 1.3-fold (0.12 log units) above; low and high end bracket the measured number.
By their numbers in this assay, from the lowest: compounds 1, 2 and 4 (each within the scatter of the next, the first and the last beyond it); then compound 3.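

Chloro in place of hydrogen on the sulfonyl side now has a direct reading of its own in this assay, a modest step but one beyond the scatter (a 2.5-fold lower number from compound 3 to compound 4 (0.40 log units; beyond the scatter)). With that chloro held fixed, the group on the other ring can now be compared for methoxy as well: methoxy in place of bromo leaves the two compounds within the scatter of each other (a 1.0-fold higher number from compound 2 to compound 4 (0.01 log units; within the scatter)), while methoxy in place of fluoro gives a modest step beyond it (a 2.0-fold higher number from compound 1 to compound 4 (0.31 log units; beyond the scatter)). Nothing measured here gives a reason for any of these numbers.

This reading of the chloro rests on a single pair with methoxy on the other ring, so its size with fluoro or bromo on that ring remains an open question. On the sulfonyl side the compounds shown carry only hydrogen or chloro, which leaves open how a larger or differently built group there, such as an amine, a carboxylic acid or a longer alkyl chain, would change the number.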